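Notes on a series held at the assay limit

The source may report more compounds than this note shows. Statements on the series, on what has been measured and on what is new or still open speak of the compounds shown alone.

- compound 1 `COc1cc(-c2ncnn2-c2cccc(F)c2)cc(OC)c1OC`: > 10000 nM
- compound 2 `COc1cc(-c2ncnn2-c2cccc(N)c2)cc(OC)c1OC`: > 10000 nM

Both entries come from a functional assay on HeLa cells (Homo sapiens) for antiproliferative activity, read by MTT assay, with a stated time of 72 h; on this read-out higher numbers stand for weaker inhibition and lower numbers for stronger inhibition. Compound 1 gives > 10000 nM, which is a limit and not a number. Compound 2 gives > 10000 nM, again only a limit, so its standing in the series cannot be given as a number.

The next compound is compound 3 `COc1cc(-c2ncnn2-c2ccc(F)cc2)cc(OC)c1OC`, with 4-fluorophenyl in place of 3-aminophenyl on an aromatic nitrogen.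

Going by the values given here, the only measured step is a step that the two limits leave unreadable from compound 1 to compound 2, and it offers no size to carry over. Among the compounds with values here, the series so far shows only (the limit of > 10000 nM in this assay, at which 2 of the 2 values shown sit), so compound 3 is expected to stay close to that limit, with no firm direction. The step expected in this assay is a number no higher from compound 2 to compound 3 (the limit leaves the size open). For compound 3 the estimate is 10000 nM, with an expected range from 2000 nM to 30000 nM.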

Compound 3, half-maximal inhibitory concentration: > 10000 nM
Compound 3: a limit, no number; the forecaster's own chance of this, stated with the estimate: 70%; the middle value lies on the limit itself.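

Going by these compounds alone, compound 3 gives > 10000 nM in this assay and this is a limit, not a number, so no step among compound 1, compound 2 and compound 3 can be read. Still open, as far as these compounds go, is whether, in this assay here, any other group on the aromatic nitrogen would give a readable number.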